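Mirror image and a hydroxy for fluoro on a shared core

The source may report more compounds than this note shows. Statements on the series, on what has been measured and on what is new or still open speak of the compounds shown alone.

The study examines a small set of polyhydroxylated pyrrolidines carrying an aryl group, in an assay on isolated protein for inhibition of alpha-galactosidase (Coffea arabica), tested at 1000 uM; a lower number here means less inhibition, a higher number more inhibition at the concentration tested (going by the name of the read-out). Compound 1 `OC[C@@]1(c2ccc(F)cc2)NC[C@@H](O)[C@@H]1O` gives 0%. Compound 2 `OC[C@]1(c2ccc(F)cc2)NC[C@H](O)[C@H]1O` gives 0%. Within the data shown here, the step of no change at the digits printed from compound 1 to compound 2 (within the scatter) is the only measured step here, and it rests on the fact that compounds 1 and 2 differ only in the configuration as drawn alone; compound 2 therefore stands level with compound 1, with no inhibition recorded for either in this assay.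

The next compound, compound 3 `OC[C@]1(c2ccc(O)cc2)NC[C@H](O)[C@H]1O`, keeps the ring configuration of compound 2 and differs from it by hydroxy in place of fluoro on an aromatic carbon. Among the measured compounds shown here, no measured step in this set touches the aromatic substituent, so the measured data say nothing about the size or direction of the effect of this change; the only precedent, the mirror-image step, left the read-out unchanged. The account therefore expects that compound 3 stays close to compound 2, with the step of a number 5 percentage points higher from compound 2 to compound 3 (within the scatter) estimated as nothing beyond the scatter. Compound 3 is thus estimated at 5% in this assay, within a range from 0% to 25%.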

Compound 3, a percentage reported as inhibition, at one concentration (the size of the read-out at that concentration, not a potency): 3.6%
Beside the measured number, compound 3's estimate is 1.4 percentage points above it, and the stated range covers the measured number.
By their numbers in this assay, from the lowest: compounds 1, 2 and 3 (each within the scatter of the next).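

In this assay, among these compounds, the exchange of fluoro for hydroxy on an aromatic carbon gives a number 3.6 percentage points higher from compound 2 to compound 3 (within the scatter), which makes this the first reading in the set of a change of substituent rather than of configuration. The hydroxy brings a hydrogen-bond donor and a hydrogen-bond acceptor to a place where the fluoro carried neither, yet at the concentration tested the exchange does not move the read-out beyond the scatter of repeated measurements. The information given here offers no explanation for this result.

The compounds shown leave open whether an amine, a carboxylic acid or a methoxy group at this same place on the aromatic ring would move the read-out in this assay beyond the scatter, or whether any group there would separate compounds on the shared core. Among the compounds shown here, they also leave open how the hydroxy would read on the ring configuration of compound 1, for which no step is available.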